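The compounds below may be only part of what the source reports. "The series", "measured", "known", "first", "only" and "open" are said of these compounds alone.

Measured so far in an ADME assay on microsomes from liver (Mus musculus) for metabolic stability, read by LC-MS, with a stated time of 30 min, tested at 1 uM; a higher number here means that more of the compound is left, a lower number that less of the compound is left:
- compound 1 `O=C(NCc1ccc(S(=O)(=O)c2ccccc2)cc1)c1ccc2cnccc2c1`: 10%
- compound 2 `O=C(NCc1ccc(S(=O)(=O)c2cc(F)cc(F)c2)cc1)c1cc2cnccc2[nH]1`: 63%

Compound 2, at 63%, holds the higher of the two numbers, and compound 1, at 10%, lies beyond the scatter below it. The two structures differ in more than one place, so this gap cannot be assigned to any single change.

The next compound is compound 3 `O=C(NCc1ccc(S(=O)(=O)c2cc(F)cc(F)c2)cc1)c1cc2ccncc2o1`, which departs from compound 2 in one place, on a carbonyl carbon: a group of 9 heavy atoms (7 carbon, 1 nitrogen, 1 oxygen; one five-membered aromatic ring with 1 hetero atom, one six-membered aromatic ring with 1 hetero atom) in place of a group of 9 heavy atoms (7 carbon, 2 nitrogen; one five-membered aromatic ring with 1 hetero atom, one six-membered aromatic ring with 1 hetero atom), on a carbonyl carbon. Everything outside this group stays the same. Within the data shown here, no measured single-place step is available in this set, so the size of the step can only be judged loosely. A small fall in this assay is expected, most likely none beyond the scatter, and the expectation is anchored on compound 2 at 63%. An expected change of a number 8 percentage points lower from compound 2 to compound 3 (within the scatter) is estimated. The range is kept wide, since compound 1 at 10% shows how low the values can reach. For compound 3 the expected value is 55%, with an estimated range of 33% to 76%.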

Compound 3, percent of the compound remaining: 12%
Estimate against measurement, compound 3: 43 percentage points above; measured number below the stated range.
By their numbers in this assay, from the lowest: compounds 1 and 3 (each within the scatter of the next); then compound 2.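

In this assay, among these compounds, the exchange on the carbonyl carbon gives a number 51 percentage points lower from compound 2 to compound 3 (beyond the scatter), the first step that can be tied to a single place. This place therefore matters in this assay, even between two groups with the same count of 9 heavy atoms and the same pair of rings, one five-membered aromatic ring with 1 hetero atom and one six-membered aromatic ring with 1 hetero atom; what differs is that the leaving group has 2 nitrogen atoms, 1 hydrogen-bond donor and 1 hydrogen-bond acceptor, while the entering group has 1 nitrogen atom, 1 oxygen atom, 0 hydrogen-bond donors and 2 hydrogen-bond acceptors. No measurement at hand bears on the reason for this step.

As far as these compounds go, whether the step follows the loss of the hydrogen-bond donor or the oxygen atom itself stays open, and a methyl group on the nitrogen of the five-membered ring of compound 2 would separate the two. Among the compounds shown here, also open is whether the exchange keeps its size with other groups on the rest of the structure, as this is the only single-place step available.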